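Solubility of a Shared Core: tert-Butyl in Place of Benzyl

The compounds below may be only part of what the source reports. "The series", "measured", "known", "first", "only" and "open" are said of these compounds alone.

Of the compounds shown here, three built on one shared core have been measured in a physicochemical assay for solubility, in phosphate buffer, with a stated time of 18 h; on this read-out lower numbers stand for lower solubility and higher numbers for higher solubility. Compound 1 `CC(C)c1ncc2c(N)c(C#N)c(N)nc2n1` carries an isopropyl group, and in this assay compound 1 sits at > 1000000 nM, a limit of the assay rather than a number (the limit of > 1000000 nM in this assay, at which 1 of the 3 values shown sits). Compound 2 `N#Cc1c(N)nc2nc(C3CCCC3)ncc2c1N` carries a cyclopentyl group and gives 89000 nM. Compound 3 `N#Cc1c(N)nc2nc(Cc3ccccc3)ncc2c1N` carries a benzyl group and gives 13000 nM, the lowest of the numbers shown. The steps between them were all beyond the scatter: an at least 11-fold lower number from compound 1 to compound 2 (1.05 log units; beyond the scatter), an at least 76-fold lower number from compound 1 to compound 3 (1.88 log units; beyond the scatter), and a 6.8-fold lower number from compound 2 to compound 3 (0.84 log units; beyond the scatter).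

Compound 4 `CC(C)(C)c1ncc2c(N)c(C#N)c(N)nc2n1` has not yet been measured. It differs from compound 3 in one place: tert-butyl in place of benzyl on an aromatic carbon. This change runs opposite to the earlier move that produced compound 3, where benzyl replaced isopropyl, and tert-butyl is a small group without a ring, as isopropyl is. The most relevant guide is therefore an at least 76-fold lower number from compound 1 to compound 3 (1.88 log units; beyond the scatter) read backwards, with an at least 11-fold lower number from compound 1 to compound 2 (1.05 log units; beyond the scatter) as a second pointer; both were large. A large rise in solubility is expected, and the expected step is a 46-fold higher number from compound 3 to compound 4 (1.66 log units; beyond the scatter). The estimate for compound 4 is 600000 nM, with a range from 150000 nM to 1500000 nM, and a real chance that the assay again reports only its limit.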

Compound 4, solubility: 37200 nM
Compound 4: middle estimate off by 16-fold (1.21 log units), on the high side; the measured number lies below the stated range.
By their numbers in this assay, from the lowest: compound 3; then compound 4; then compound 2. At a limit, above all of these: compound 1.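

In this assay, one added methyl on the isopropyl group is already a large change at this aromatic carbon, giving an at least 26-fold lower number from compound 1 to compound 4 (1.42 log units; beyond the scatter). Compound 1 stands at a limit of the assay, not at a number: the limit of > 1000000 nM in this assay, at which 1 of the 4 values shown sits. Having no ring does not by itself keep the number high: the change to tert-butyl gives only a 2.9-fold higher number from compound 3 to compound 4 (0.46 log units; beyond the scatter), and the other comparison gives a 2.4-fold lower number from compound 2 to compound 4 (0.38 log units; beyond the scatter), so compound 4, which has no ring, falls under compound 2 with its cyclopentyl ring and above compound 3 with its benzyl ring.

The groups shown at this position contain only carbon and hydrogen, so it remains open how an amine, a carboxylic acid or a methoxyethyl chain would read out there. Also open, going by these compounds, are the true solubility of compound 1 and whether the order of these groups would hold in a different buffer or over a different time.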